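Side-chain amines on the shared core: expectation for compound 3

This account rests on a few compounds, and the source may have more. Where it says the series, first, only, none or still open, it means among the compounds named here.

Measured so far in a functional assay on SH-SY5Y cells (Homo sapiens) for cytotoxicity, read by MTT assay, with a stated time of 72 h; on this read-out lower numbers stand for stronger inhibition and higher numbers for weaker inhibition:
compound 1, `O=C1c2c[n+]([O-])c3ccccc3c2C(=O)c2c1c1ccccc1n2Cc1cn(C[C@@H](O)CO)nn1`: > 500 nM
compound 2, `O=C1c2c[n+]([O-])c3ccccc3c2C(=O)c2c1c1ccccc1n2CCCCN1CCNCC1`: 1240 nM

Compound 1 returns only a limit in this assay, > 500 nM, not a number. Compound 2 gives 1240 nM, the only number shown for the series, so its standing cannot be placed against any other measured compound. The single step shown, a step that the limit leaves unreadable from compound 1 to compound 2, cannot be read in size because the limit of > 500 nM in this assay, at which 1 of the 2 values shown sits, leaves the start of the step open.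

Compound 3, `O=C1c2c[n+]([O-])c3ccccc3c2C(=O)c2c1c1ccccc1n2CCN1CCCC1`, differs from compound 2 by pyrrolidin-1-yl in place of 2-(piperazin-1-yl)ethyl on a saturated chain carbon, two bonds along the chain from an aromatic nitrogen. No measured step bears on this change: the one step shown concerns a different pair of groups and is itself unreadable. The expectation therefore rests on compound 2 alone, with no support for a shift in either direction beyond the scatter. Compound 3 is expected to sit near compound 2, at an estimated 1500 nM, within a range of 500 nM to 4500 nM. The step of a 1.2-fold higher number from compound 2 to compound 3 (0.08 log units; within the scatter) is thus expected to stay within the scatter of repeated measurements.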

Compound 3, half-maximal inhibitory concentration: 520 nM
Estimate against measurement, compound 3: 2.9-fold (0.46 log units) above; low and high end bracket the measured number.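

In this assay, the series now has its first readable step, a 2.4-fold lower number from compound 2 to compound 3 (0.38 log units; beyond the scatter), so a change in this side chain can move the read-out beyond the scatter, towards stronger inhibition. Read one bond further out, the same difference is 4-(piperazin-1-yl)butyl to 2-(pyrrolidin-1-yl)ethyl, so the amine ring and the chain change together, and this single step assigns the shift to neither of them. The steps starting from compound 1 remain unreadable, because compound 1 returns a limit and not a number: the limit of > 500 nM in this assay, at which 1 of the 3 values shown sits.

On these data alone, whether the shift follows the ring or the chain stays open, and a 4-(pyrrolidin-1-yl)butyl or a 2-(piperazin-1-yl)ethyl side chain on the shared core would separate the two. Also open is how an open-chain amine such as diethylamino, or a piperidine ring, at the end of the chain would compare with pyrrolidin-1-yl in this assay, as neither group is among the compounds shown.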